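Working notes: from compound 3 to compound 4

This account rests on a few compounds, and the source may have more. Where it says the series, first, only, none or still open, it means among the compounds named here.

Values in a functional assay on HCT-116 cells (Homo sapiens) for antiproliferative activity, read by MTT assay, with a stated time of 72 h (on this read-out lower numbers stand for stronger inhibition and higher numbers for weaker inhibition), for the measured compounds:
- compound 1 `O=C(CCc1cccc2c1B(O)OC2)Nc1cccc(Br)c1` gives 1400 nM 
- compound 2 `O=C(CCc1cccc2c1B(O)OC2)Nc1cccc(-c2ccccc2)c1` gives 890 nM 
- compound 3 `COc1ccc(-c2cccc(NC(=O)CCc3cccc4c3B(O)OC4)c2)cc1` gives 160 nM 

Compound 3 holds the lowest number of the three, and its gaps to compound 1 and compound 2 both lie beyond the scatter. The next structure, compound 4 `COc1cc(OC)cc(-c2cccc(NC(=O)CCc3cccc4c3B(O)OC4)c2)c1`, carries 3,5-dimethoxyphenyl in place of 4-methoxyphenyl on an aromatic carbon, and the counted difference is 3,5-dimethoxyphenyl in place of 4-methoxyphenyl on an aromatic carbon with the rest of the molecule unchanged.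

For the measured compounds named here, three measured steps bear on this change. Phenyl in place of bromo gave a 1.6-fold lower number from compound 1 to compound 2 (0.20 log units; within the scatter) and so no clear change. 4-Methoxyphenyl in place of bromo gave an 8.8-fold lower number from compound 1 to compound 3 (0.94 log units; beyond the scatter) as the largest step in the set. Methoxy in place of hydrogen gave a 5.6-fold lower number from compound 2 to compound 3 (0.75 log units; beyond the scatter) and is the closest precedent, since it also concerns a methoxy group on the outer ring. Going by the values given here, no measured compound shows a second methoxy group or a methoxy group in another place, so the direction remains open. A modest loss is slightly more likely than a gain, but no step beyond the scatter is expected in this assay for this change. The expected result is a 1.3-fold higher number from compound 3 to compound 4 (0.10 log units; within the scatter) on current evidence. For compound 4 the estimated value is 200 nM with an expected range from 60 nM to 700 nM in these notes.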

Compound 4, half-maximal inhibitory concentration: 53 nM
The estimate for compound 4 lay 3.8-fold (0.58 log units) above the measured number, outside the stated range (below it).
By their numbers in this assay, from the lowest: compound 4; then compound 3; then compounds 2 and 1 (each within the scatter of the next).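

In this assay, for the compounds shown here, 3,5-dimethoxyphenyl in place of 4-methoxyphenyl gives a 3.0-fold lower number from compound 3 to compound 4 (0.48 log units; beyond the scatter), so the outer ring at this position still has room for improvement beyond the single methoxy group of the earlier compounds. A methoxy group in the place it holds in 4-methoxyphenyl is also not required for a low number, since the 3,5-dimethoxyphenyl ring has none there and still gives the lowest value of the series. Measured against the unsubstituted outer ring and the bromo compound, the change gives a 17-fold lower number from compound 2 to compound 4 (1.23 log units; beyond the scatter) and a 26-fold lower number from compound 1 to compound 4 (1.42 log units; beyond the scatter), which extends the trend among these four compounds, with no compound against it, of lower numbers as methoxy groups are added to the outer ring.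

The data shown give no cause for this gain. From the compounds shown here alone, the effect of adding a second methoxy group cannot be told apart from that of moving the methoxy groups, and it remains open whether hydroxy or an amine in place of methoxy on this ring would keep the number as low.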